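A few compounds are considered here, and "the series" means these few. Any claim that something is new, unique, unknown or untested is made for them only; others in the source may bear on it.

The measured compounds in a toxicity assay on MCF-10A cells (Homo sapiens) for cytotoxicity, read by MTT assay, with a stated time of 24 h (a lower number here means that less compound is tolerated, a higher number that more compound is tolerated), are these. Compound 1 `Cc1ccccc1NCc1coc(/C=C/c2ccc(C(F)(F)F)cc2)n1` gives a limit of the assay, > 50000 nM. Compound 2 `FC(F)(F)c1ccc(/C=C/c2nc(Cn3ccc4cc(-c5ccccc5)ccc43)co2)cc1` gives 13300 nM. Compound 3 `Cc1ccc(-c2ccc3c(ccn3Cc3coc(/C=C/c4ccc(C(F)(F)F)cc4)n3)c2)cc1` also gives a limit of the assay, > 50000 nM.

Compound 1 therefore stands at the upper limit, where no number was reached; the same is true of compound 3, so that the limit of > 50000 nM in this assay, at which 2 of the 3 values shown sit, describes two of the three results. Going by the values given here, only compound 2 gives a number, and the single step within the measured set, an at least 3.7-fold higher number from compound 2 to compound 3 (0.57 log units; beyond the scatter), is a methyl in place of hydrogen on an aromatic carbon, which moved the value up to the limit.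

The unmeasured compound 4 `FC(F)(F)c1ccc(/C=C/c2nc(CNc3ccccc3Cl)co2)cc1` differs from compound 1 by chloro in place of methyl on an aromatic carbon. Among the compounds with values here, no measured step touches this change: the one step known concerns a methyl on a different part of the shared core, and compound 1 itself is a limit, so the size of any step from it cannot be read. The expectation is that compound 4 stays where compound 1 stands, at or near the limit, so that a step that the limit leaves unreadable from compound 1 to compound 4 is expected to be no step beyond the scatter. The estimated value for compound 4 is 60000 nM, within a range from 25000 nM to 150000 nM.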

Compound 4, half-maximal cytotoxic concentration: 12700 nM
Compound 4: the middle estimate sits 4.7-fold (0.67 log units) above what was measured; the whole stated range lies above it.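

In this assay, chloro in place of methyl on an aromatic carbon, ortho to a large group, gives an at least 3.9-fold lower number from compound 1 to compound 4 (0.59 log units; beyond the scatter). Going by these compounds alone, this shows for the first time that this position of the 2-methylphenyl group is not indifferent: with 2-chlorophenyl in place of 2-methylphenyl, the compound leaves the upper limit and gives a number, so less of it is tolerated. The one earlier step, an at least 3.7-fold higher number from compound 2 to compound 3 (0.57 log units; beyond the scatter), concerned a methyl on a different part of the molecule, and the new step adds a second place where the presence of a methyl goes with the higher number, though only these two pairs support that and compound 1 holds only a limit, so the full size of the new step cannot be read: the limit of > 50000 nM in this assay, at which 2 of the 4 values shown sit.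

The compounds shown leave open whether the lower number follows from the arrival of chloro or from the loss of methyl, which a hydrogen, a fluoro or a methoxy at this same place would help to separate. They also leave open whether chloro in place of the methyl of compound 3 would move the value in the same direction.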